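Hydroxy to Chloro on the Outer Ring

The source may hold more compounds than are shown below. What is called first, only, known or untested is meant among the compounds shown, and "the series" means these compounds.

Compound 2 `O=C(/C=C/c1cc2ccccc2[nH]c1=O)c1ccc(O)cc1` and compound 1 `COc1ccc(C(=O)/C=C/c2cc3ccccc3[nH]c2=O)cc1` share one core and differ only in a single group on the outer ring. In a functional assay on U-251 cells (Homo sapiens) for cytotoxicity, read by sulforhodamine B assay, with a stated time of 24 h (on this read-out lower numbers stand for stronger inhibition of growth and higher numbers for weaker inhibition of growth), compound 1 gives 2700 nM, and compound 2 gives 2600 nM. The step of a 1.0-fold lower number from compound 1 to compound 2 (0.02 log units; within the scatter) lies within the scatter, so compound 2 sits level with compound 1 rather than apart from it. Compound 3 `O=C(/C=C/c1cc2ccccc2[nH]c1=O)c1ccc(Cl)cc1` goes one change further: chloro in place of hydroxy on an aromatic carbon. Among the compounds with values here, no measured step here removes an oxygen-bearing group entirely; the only step on record swaps methyl for hydrogen on that oxygen, so it is a loose guide at best. Because a 1.0-fold lower number from compound 1 to compound 2 (0.02 log units; within the scatter) is flat, the expectation is that compound 3 also stays near compound 2. The step is estimated as a 1.3-fold lower number from compound 2 to compound 3 (0.11 log units; within the scatter). Compound 3 is therefore expected at 2000 nM, with a range from 700 nM to 6000 nM.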

Compound 3, concentration for 50% growth inhibition: 2520 nM
Estimate against measurement, compound 3: 1.3-fold (0.10 log units) below; the range from low to high includes it.
By their numbers in this assay, from the lowest: compounds 3, 2 and 1 (each within the scatter of the next).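

Compound 3 puts a group with no oxygen at this place, on an aromatic carbon para to a large group, whereas compound 1 and compound 2 both carry an oxygen there. In this assay the change to chloro reads a 1.0-fold lower number from compound 2 to compound 3 (0.01 log units; within the scatter) against hydroxy and a 1.1-fold lower number from compound 1 to compound 3 (0.03 log units; within the scatter) against methoxy, so among these three compounds the oxygen, and the hydrogen-bond donor and acceptor that hydroxy counts, can go while the numbers stay level. Nothing available here explains why these three compounds sit together.

On these data alone, what an amine or a carboxylic acid would do at this place remains open. So does a longer chain, which would show whether a larger group on this carbon also stays level.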